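The compounds below may be only part of what the source reports. "The series", "measured", "known", "first", "only" and "open" are said of these compounds alone.

Compound 1 `COc1ccc2c(/C=C/C(=O)c3cc(N)c(OC)c(OC)c3)c[nH]c2c1` gives 186 nM
Compound 2 `COc1cc(C(=O)/C=C/c2c[nH]c3ccccc23)cc(SC)c1OC` gives 131 nM
Compound 3 `COc1cc(C(=O)/C=C/c2cn(C)c3ccccc23)cc(N)c1OC` gives 289 nM

All three values come from a functional assay on MHCC97H cells (Homo sapiens) for antiproliferative activity, read by MTT assay, with a stated time of 48 h; a lower number here means a stronger inhibitor, a higher number a weaker inhibitor. Compound 3 (value 289 nM) lies within the usual scatter of compound 1 (value 186 nM). Compound 2 (value 131 nM) has a lower number than compound 3, and that gap lies beyond the scatter.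

Compound 4 `COc1cc(C(=O)/C=C/c2c[nH]c3ccccc23)cc(N)c1OC` has hydrogen in place of methyl on an aromatic nitrogen of compound 3 (hydrogen in place of methyl on an aromatic nitrogen). For the measured compounds named here, no two measured compounds differ by this change alone, so its effect in this assay has not been seen directly. Going by the values given here, the only guide is that compound 1 (value 186 nM) and compound 2 (value 131 nM) both carry that hydrogen, although each also differs from compound 4 elsewhere. A modest move towards a lower number is therefore expected, probably not beyond the scatter. The estimated step is a 1.9-fold lower number from compound 3 to compound 4 (0.28 log units; within the scatter) (an expectation only). Compound 4 is expected at 150 nM (estimated range 60 nM to 370 nM).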

Compound 4, half-maximal inhibitory concentration: 263 nM
The estimate for compound 4 lay 1.8-fold (0.24 log units) below the measured number; the measured number falls inside the stated range.
By their numbers in this assay, from the lowest: compounds 2, 1, 4 and 3 (each within the scatter of the next, the first and the last beyond it).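

In this assay the swap of methyl for hydrogen on the aromatic nitrogen can now be read directly as a 1.1-fold lower number from compound 3 to compound 4 (0.04 log units; within the scatter) so in this pair the two groups cannot be told apart at this position. For the compounds shown here, two changes on aromatic carbons can also be read for the first time, and neither is separated from the scatter: amino in place of methylsulfanyl gives a 2.0-fold higher number from compound 2 to compound 4 (0.30 log units; within the scatter) and hydrogen in place of methoxy gives a 1.4-fold higher number from compound 1 to compound 4 (0.15 log units; within the scatter) even though the first sits right at its edge. No supporting measurement is available to explain any of these results.

The compounds shown carry only hydrogen or methyl on that aromatic nitrogen, so the outcome with a longer chain such as butyl there remains open. Whether the nitrogen swap would behave the same way on the core of compound 1 or compound 2 is also unknown.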